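The compounds below may be only part of what the source reports. "The series", "measured", "known", "first", "only" and "open" are said of these compounds alone.

Measured compounds in this series:

compound 1 `COc1ccc(-n2cc(COc3cccc(NC(=O)Nc4ccc(Cl)c(C(F)(F)F)c4)c3)nn2)cc1` — 4680 nM
compound 2 `CCc1ccccc1-n1cc(COc2cccc(NC(=O)Nc3ccc(Cl)c(C(F)(F)F)c3)c2)nn1` — 3530 nM
compound 3 `N#Cc1ccc(-n2cc(COc3cccc(NC(=O)Nc4ccc(Cl)c(C(F)(F)F)c4)c3)nn2)cc1` — 2980 nM

All three share one core and differ only in the aryl group carried on the aromatic nitrogen. In a functional assay on HepG2 cells (Homo sapiens) for inhibition, read by MTT assay, with a stated time of 72 h (a lower number here means a stronger inhibitor, a higher number a weaker inhibitor), compound 1 gives 4680 nM, compound 2 gives 3530 nM and compound 3 gives 2980 nM. Compound 3 holds the lowest of the three numbers, yet both of its steps, a 1.6-fold lower number from compound 1 to compound 3 (0.20 log units; within the scatter) and a 1.2-fold lower number from compound 2 to compound 3 (0.07 log units; within the scatter), fall within the scatter, so the three compounds cannot be ordered on these data.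

Compound 4 `CC(C)c1ccc(-n2cc(COc3cccc(NC(=O)Nc4ccc(Cl)c(C(F)(F)F)c4)c3)nn2)cc1` differs from compound 3 in isopropyl in place of cyano on an aromatic carbon. The step that bears most directly on this change is a 1.6-fold lower number from compound 1 to compound 3 (0.20 log units; within the scatter), which likewise exchanges the group on an aromatic carbon of the same ring; the step of a 1.3-fold lower number from compound 1 to compound 2 (0.12 log units; within the scatter), which replaces the whole aryl group, is the other comparison available. Neither step moved this assay beyond the scatter, and the measured compounds give no case of an isopropyl group on this ring. The expectation for compound 4 is therefore a step of a 1.2-fold higher number from compound 3 to compound 4 (0.07 log units; within the scatter) that stays within the scatter. Compound 4 is estimated at 3500 nM in this assay, with a range from 1500 nM to 8000 nM.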

Compound 4, half-maximal inhibitory concentration: 2470 nM
Beside the measured number, compound 4's estimate is 1.4-fold (0.15 log units) above it, within the range that was stated.
By their numbers in this assay, from the lowest: compounds 4, 3, 2 and 1 (each within the scatter of the next).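

The aryl group on the aromatic nitrogen now has an all-carbon, branched substituent on an aromatic carbon, para to a large group, and in this assay the exchange of cyano for isopropyl gives a 1.2-fold lower number from compound 3 to compound 4 (0.08 log units; within the scatter). The same position also tolerates the exchange of methoxy for isopropyl, with a 1.9-fold lower number from compound 1 to compound 4 (0.28 log units; within the scatter), and moving from the 2-ethylphenyl group to the 4-isopropylphenyl group gives a 1.4-fold lower number from compound 2 to compound 4 (0.16 log units; within the scatter), so cyano, methoxy and isopropyl at this carbon, and the 2-ethylphenyl group, cannot be told apart in this series. No measurement is available that bears on why this position responds so little.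

From the compounds shown here alone, whether an amine, a carboxylic acid or a longer alkyl chain on this carbon would give a step beyond the scatter remains open, as does the effect of a second substituent on the same ring. The four compounds also share the rest of the core unchanged, so they leave open how the numbers respond to changes in the urea or in the ring bearing chloro and trifluoromethyl.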